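Alkyne substituent and microsomal clearance in the spirocyclic series

A few compounds are considered here, and "the series" means these few. Any claim that something is new, unique, unknown or untested is made for them only; others in the source may bear on it.

Measured compounds in an ADME assay on microsomes from liver (Homo sapiens) for metabolic stability, read by LC-MS, using NADPH, with a stated time of 30 min, tested at 1 uM; on this read-out lower numbers stand for slow clearance and higher numbers for fast clearance:
compound 1 `CC#Cc1cncc(-c2ccc3c(c2)[C@@]2(COC(N)=N2)c2cc(Cl)ncc2O3)c1`, 27 mL.min-1.g-1
compound 2 `CC1(C#Cc2cncc(-c3ccc4c(c3)[C@@]3(COC(N)=N3)c3cc(C5=CCOCC5)ncc3O4)c2)COC1`, 420 mL.min-1.g-1
compound 3 `CC#Cc1cncc(-c2ccc3c(c2)[C@@]2(COC(N)=N2)c2cc(C4=CCCOC4)ncc2O3)c1`, 76 mL.min-1.g-1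

Compound 2 stands highest of the three numbers in this assay; the nearest is compound 3, and compound 1 is furthest. Within the data shown here, the only single-point step measured so far is a 2.8-fold higher number from compound 1 to compound 3 (0.45 log units; beyond the scatter), which concerns the substituent on the aromatic carbon and not the alkyne end of the molecule. Compound 2 and compound 3 differ in two places, so their values show only that the pairing of the 2-(3-methyloxetan-3-yl)ethynyl group with the six-membered non-aromatic ring goes with the highest number seen.

Compound 4 `NC1=N[C@@]2(CO1)c1cc(-c3cncc(C#CC4CC4)c3)ccc1Oc1cnc(C3=CCOCC3)cc12` is obtained from compound 2 by the change (cyclopropyl in place of 3-methyloxetan-3-yl on a triple-bonded carbon). Among the measured compounds shown here, no measured step bears directly on this change. The expectation therefore rests on compound 2 giving 420 mL.min-1.g-1 and on the lower numbers of compounds 1 and 3, which carry smaller alkyne ends. A lower number is expected for compound 4 in this assay, with a step of a 2.6-fold lower number from compound 2 to compound 4 (0.42 log units; beyond the scatter). The estimate for compound 4 is 160 mL.min-1.g-1, in the range 55 mL.min-1.g-1 to 420 mL.min-1.g-1.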

Compound 4, intrinsic clearance in microsomes: 80 mL.min-1.g-1
Compound 4: the middle estimate sits 2.0-fold (0.30 log units) above what was measured; measured number inside the range.
By their numbers in this assay, from the lowest: compound 1; then compounds 3 and 4 (each within the scatter of the next); then compound 2.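

Notes on the alkyne end: in this assay, cyclopropyl in place of 3-methyloxetan-3-yl on a triple-bonded carbon gives a 5.3-fold lower number from compound 2 to compound 4 (0.72 log units; beyond the scatter), the first step read at this end of the molecule. The group on the aromatic carbon is the same in both compounds, so the high number of compound 2 does not follow from that six-membered ring alone and depends on the alkyne substituent as well. No data here bear on the reason for this drop.

The compounds shown leave open whether the step would hold with a different group on the aromatic carbon, such as the chlorine of compound 1. They also leave open where a tert-butyl group or a dimethylamino group on the same triple-bonded carbon would stand.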